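The compounds below may be only part of what the source reports. "The series", "measured", "known", "first", "only" and "open" are said of these compounds alone.

Compound 1 `Cc1ccc(S(=O)(=O)/N=C(/CCNC2=CC(=O)c3ccccc3C2=O)Nc2ccc(F)cc2)cc1` gives 4260 nM in a functional assay on MCF7 cells (Homo sapiens) for cytotoxicity, read by MTT assay, with a stated time of 48 h (on this read-out higher numbers stand for weaker inhibition and lower numbers for stronger inhibition), the lowest number of the three measured compounds. Compound 2 `COc1ccc(N/C(CCNC2=CC(=O)c3ccccc3C2=O)=N\S(=O)(=O)c2ccc(C)cc2)c(OC)c1` gives 30200 nM and compound 3 `Cc1ccc(S(=O)(=O)/N=C(/CCNC2=CC(=O)c3ccccc3C2=O)NC(C)C)cc1` gives 16500 nM. Compound 4 `Cc1ccc(S(=O)(=O)/N=C(/CCNC2=CC(=O)c3ccccc3C2=O)NC2CCCCC2)cc1` differs from compound 1 in one place: cyclohexyl in place of 4-fluorophenyl on an amine nitrogen. Among the compounds with values here, two measured steps bear on this. The step of a 7.1-fold higher number from compound 1 to compound 2 (0.85 log units; beyond the scatter) and the step of a 3.9-fold higher number from compound 1 to compound 3 (0.59 log units; beyond the scatter) both raised the number, so each replacement of the 4-fluorophenyl on an amine nitrogen tried so far weakened inhibition. Cyclohexyl is a six-membered non-aromatic ring of carbon only, closest in kind to the isopropyl of compound 3, and because a 3.9-fold higher number from compound 1 to compound 3 (0.59 log units; beyond the scatter) was modest, a modest rise is expected for compound 4 as well, as a 3.3-fold higher number from compound 1 to compound 4 (0.52 log units; beyond the scatter). Compound 4 is therefore estimated at 14000 nM, within a range of 5000 nM to 40000 nM.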

Compound 4, half-maximal inhibitory concentration: 7580 nM
Beside the measured number, compound 4's estimate is 1.8-fold (0.27 log units) above it; low and high end bracket the measured number.
By their numbers in this assay, from the lowest: compounds 1 and 4 (each within the scatter of the next); then compounds 3 and 2 (each within the scatter of the next).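

In this assay, an aromatic ring on this amine nitrogen proves not to be required: the non-aromatic cyclohexyl stays level with 4-fluorophenyl (a 1.8-fold higher number from compound 1 to compound 4 (0.25 log units; within the scatter)). Non-aromatic groups at this place are not interchangeable, since cyclohexyl gives a lower number than isopropyl (a 2.2-fold lower number from compound 3 to compound 4 (0.34 log units; beyond the scatter)) and also a lower number than 2,4-dimethoxyphenyl (a 4.0-fold lower number from compound 2 to compound 4 (0.60 log units; beyond the scatter)). No supporting measurement accounts for these differences.

From the compounds shown here alone, whether plain phenyl would match 4-fluorophenyl remains open. So does the outcome for cyclopentyl, benzyl or a longer chain such as n-butyl on this nitrogen.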